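Three close values and a new side group

The source may report more compounds than this note shows. Statements on the series, on what has been measured and on what is new or still open speak of the compounds shown alone.

Of the compounds shown here, three sharing one core have been tested in a functional assay on HepG2 cells (Homo sapiens) for inhibition, read by MTT assay, with a stated time of 3 days; a higher number here means a weaker inhibitor, a lower number a stronger inhibitor. Compound 1 `COc1cc(-c2nc3ccccc3s2)ccc1OCC(=O)NNC(O)CN(C)CC(=O)O` gives 3030 nM, compound 2 `CC[C@H](C)[C@@H](NCC(=O)NNC(=O)COc1ccc(-c2nc3ccccc3s2)cc1OC)C(=O)O` gives 3990 nM, and compound 3 `COc1cc(-c2nc3ccccc3s2)ccc1OCC(=O)NNC(=O)CN(C(C)=O)[C@@H](CS)C(=O)O` gives 3420 nM. Compound 3 thus lies within the usual scatter of both other compounds, and these numbers set no order among the three.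

Compound 4 `CCOC(=O)[C@H](NCC(=O)NNC(=O)COc1ccc(-c2nc3ccccc3s2)cc1OC)[C@@H](C)CC` has not yet been measured. Its structure differs from that of compound 3 in one place: (1-(ethoxycarbonyl)-2-methylbutyl)amino in place of acetyl(1-carboxy-2-sulfanylethyl)amino on a saturated chain carbon bound to a carbonyl carbon.

For the measured compounds named here, one measured step bears on this change, as it concerns the same place and the same acetyl(1-carboxy-2-sulfanylethyl)amino group: a 1.2-fold lower number from compound 2 to compound 3 (0.07 log units; within the scatter). That step is small and stays within the scatter. Going by the values given here, no measured compound carries the (1-(ethoxycarbonyl)-2-methylbutyl)amino group, however, so a larger shift cannot be ruled out.

The expected outcome in this assay is no step beyond the scatter, with an estimated 1.1-fold lower number from compound 3 to compound 4 (0.03 log units; within the scatter). For compound 4 the estimate is 3200 nM, with an expected range of 1400 nM to 7500 nM.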

Compound 4, half-maximal inhibitory concentration: 3970 nM
Compound 4: the middle estimate sits 1.2-fold (0.09 log units) below what was measured, and the stated range covers the measured number.
By their numbers in this assay, from the lowest: compounds 1, 3, 4 and 2 (each within the scatter of the next).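

In this assay, putting (1-(ethoxycarbonyl)-2-methylbutyl)amino in place of acetyl(1-carboxy-2-sulfanylethyl)amino on a saturated chain carbon bound to a carbonyl carbon gives a 1.2-fold higher number from compound 3 to compound 4 (0.06 log units; within the scatter), so even this exchange of one whole side group for another leaves the number inside the scatter. The new compound also adds a second comparison at the same place: turning the carboxylic acid into its ethyl ester gives a 1.0-fold lower number from compound 2 to compound 4 (0.00 log units; within the scatter), which means that the free acid and the ethyl ester cannot be told apart in this assay for this side group. No other measurement is available that could explain why these numbers stay so close.

The compounds shown leave open whether any group at this place can move the number beyond the scatter, for instance a free primary amine or a benzyl group in place of the present side chains. For the compounds shown here, they also leave open whether the ethyl ester would match the free acid on a different side chain, such as the one in compound 3.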